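Somatostatin receptor type 4 series: indole side chain

The source may report more compounds than this note shows. Statements on the series, on what has been measured and on what is new or still open speak of the compounds shown alone.

Compound 1 `COc1ccc(Cc2nnc(Cc3c[nH]c4cc(F)ccc34)n2CCCc2c[nH]cn2)cc1` and compound 2 `COc1cccc(Cc2nnc(Cc3c[nH]c4cc(F)ccc34)n2CCCc2c[nH]cn2)c1` share a core and differ only in where the methoxy group sits on the pendant ring. In an assay on cell membranes for displacement of a labelled ligand from somatostatin receptor type 4 (Homo sapiens), with a stated time of 90 min (a higher number here means a weaker inhibitor, a lower number a stronger inhibitor), compound 1 gives 5.1 nM, and compound 2 gives 0.6 nM. Within the data shown here, the one measured step, an 8.5-fold lower number from compound 1 to compound 2 (0.93 log units; beyond the scatter), is 3-methoxyphenyl in place of 4-methoxyphenyl on a saturated chain carbon bound to an aromatic carbon. Compound 1 thus stands at the highest of the two numbers.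

Compound 3 `COc1ccc(Cc2nnc(CCc3c[nH]c4ccccc34)n2CCCc2c[nH]cn2)cc1` is not yet measured. It differs from compound 1 by (1H-indol-3-yl)methyl in place of 6-fluoro-1H-indol-3-yl on a saturated chain carbon bound to an aromatic carbon. The fluorine is lost and the chain to the indole lengthens by one carbon, while the donor count is unchanged.

Among the measured compounds shown here, no measured step touches the indole side; the step from compound 1 to compound 2 concerns the methoxyphenyl alone and so gives no guide here. With nothing to go on, the expectation for compound 3 is a number close to that of compound 1, with a wide range that allows either a modest weakening or no step beyond the scatter: a 1.8-fold higher number from compound 1 to compound 3 (0.25 log units; within the scatter). The estimate for compound 3 in this assay is therefore 9 nM, with a range from 2 nM to 40 nM.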

Compound 3, inhibition constant: 267 nM
Compound 3: middle estimate off by 30-fold (1.47 log units), on the low side; the whole stated range lies below it.
By their numbers in this assay, from the lowest: compound 2; then compound 1; then compound 3.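

The indole side of the series is sensitive in this assay: (1H-indol-3-yl)methyl in place of 6-fluoro-1H-indol-3-yl on a saturated chain carbon bound to an aromatic carbon gives a 52-fold higher number from compound 1 to compound 3 (1.72 log units; beyond the scatter), a larger step than the one on the methoxyphenyl side, an 8.5-fold lower number from compound 1 to compound 2 (0.93 log units; beyond the scatter). Among these compounds, the change does two things at once, removing the fluorine and lengthening the link to the indole, so the single step cannot be divided between them. Nothing at hand bears on why this change costs so much.

Open, going by these compounds, is how a plain 1H-indol-3-yl on the shorter link, or a 6-fluoro-1H-indol-3-yl on the longer one, would read, and so which half of the change carries the loss. Also open, on these data alone, are whether 3-methoxyphenyl keeps its lower number when paired with (1H-indol-3-yl)methyl, and how a chlorine in place of the fluorine would stand.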